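Swapping fluoro for methoxy on compound 3

A few compounds are considered here, and "the series" means these few. Any claim that something is new, unique, unknown or untested is made for them only; others in the source may bear on it.

In a functional assay on HepG2 cells (Homo sapiens) for inhibition, read by MTT assay, with a stated time of 72 h (a lower number here means a stronger inhibitor, a higher number a weaker inhibitor), compound 1 `CC(C)(C)n1cc2c(n1)C(=O)CC1(CCN(C(=O)c3cc(-c4ccccc4)nc4ccccc34)CC1)O2` gives 2110 nM and compound 3 `CC(C)(C)n1cc2c(n1)C(=O)CC1(CCN(C(=O)c3cc(-c4ccc(F)cc4)nc4ccccc34)CC1)O2` gives 2930 nM, two values within the usual scatter of each other. Compound 2 `Cc1ccccc1-c1cc(C(=O)N2CCC3(CC2)CC(=O)c2nn(C(C)(C)C)cc2O3)c2ccccc2n1` reports only a limit, > 10000 nM. Compound 4 `COc1ccc(-c2cc(C(=O)N3CCC4(CC3)CC(=O)c3nn(C(C)(C)C)cc3O4)c3ccccc3n2)cc1` carries methoxy in place of fluoro on an aromatic carbon, para to a large group (methoxy in place of fluoro on an aromatic carbon). The closest guide is the fluoro step at that place, a 1.4-fold higher number from compound 1 to compound 3 (0.14 log units; within the scatter). The step to 2-methylphenyl, an at least 4.7-fold higher number from compound 1 to compound 2 (0.67 log units; beyond the scatter), is larger, but it involves a different group, so it bears less directly. A change within the scatter is therefore expected, an estimated 1.0-fold higher number from compound 3 to compound 4 (0.01 log units; within the scatter). For compound 4 the estimated value is 3000 nM, with an expected range of 1200 nM to 8000 nM.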

Compound 4, half-maximal inhibitory concentration: 2780 nM
Compound 4: the middle estimate sits 1.1-fold (0.03 log units) above what was measured, and the stated range covers the measured number.
By their numbers in this assay, from the lowest: compounds 1, 4 and 3 (each within the scatter of the next). At a limit, above all of these: compound 2.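

In this assay, a larger group on this aromatic carbon, para to a large group, changes little: going from fluoro to methoxy stays within the scatter (a 1.1-fold lower number from compound 3 to compound 4 (0.02 log units; within the scatter)), and so does going from hydrogen to methoxy (a 1.3-fold higher number from compound 1 to compound 4 (0.12 log units; within the scatter)). The 2-methylphenyl compound stands apart from 4-methoxyphenyl (an at least 3.5-fold lower number from compound 2 to compound 4 (0.55 log units; beyond the scatter)). The value of compound 2 is a limit, not a number: the limit of > 10000 nM in this assay, at which 1 of the 4 values shown sits.

From the compounds shown here alone, whether an amine or a carboxylic acid here would read like methoxy remains open. So does whether a longer chain would still fit this pattern.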